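Replacing the dihydroxyphenyl group of compound 1

A few compounds are considered here, and "the series" means these few. Any claim that something is new, unique, unknown or untested is made for them only; others in the source may bear on it.

Measured so far in a functional assay on DU-145 cells (Homo sapiens) for inhibition, read by trypan blue exclusion, with a stated time of 96 h (on this read-out lower numbers stand for stronger inhibition of growth and higher numbers for weaker inhibition of growth), are these compounds:
compound 1 `O=C(/C(=C\c1ccc(O)cc1O)Sc1ccc(Br)cc1)c1ccc(Cl)cc1` with 50000 nM as its value
compound 2 `COc1ccc(/C=C(/Sc2ccc(Br)cc2)C(=O)c2ccc(Br)cc2)cc1` with 25000 nM as its value
compound 3 `O=C(/C(=C\c1ccc(O)cc1O)SCc1ccc(Cl)cc1)c1ccc(Cl)cc1` with 50000 nM as its value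

Compound 1 stands level with compound 3, and compound 2 lies within the scatter of both. The step to compound 4 `Cc1cc(C)cc(/C=C(/Sc2ccc(Br)cc2)C(=O)c2ccc(Cl)cc2)c1` is 3,5-dimethylphenyl in place of 2,4-dihydroxyphenyl on a double-bonded chain carbon bound to a double-bonded chain carbon and leaves the rest of compound 1 unchanged. One measured step, no change at the digits printed from compound 1 to compound 3 (within the scatter) for a change on the sulfur, does not touch this group and so bears on it only loosely. Compound 2 at 25000 nM also lacks the 2,4-dihydroxyphenyl group, though it differs elsewhere too. The expected move in this assay is a 1.7-fold lower number from compound 1 to compound 4 (0.22 log units; within the scatter) and so no step beyond the scatter. For compound 4 the estimated value is 30000 nM with an expected range from 12000 nM to 60000 nM in all.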

Compound 4, concentration for 50% growth inhibition: 10000 nM
Estimate against measurement, compound 4: 3.0-fold (0.48 log units) above; measured number outside the range, below it.
By their numbers in this assay, from the lowest: compound 4; then compounds 2, 1 and 3 (each within the scatter of the next).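

In this assay, 3,5-dimethylphenyl in place of 2,4-dihydroxyphenyl gives a 5.0-fold lower number from compound 1 to compound 4 (0.70 log units; beyond the scatter), so this position, unlike the sulfur substituent in the earlier step of no change at the digits printed from compound 1 to compound 3 (within the scatter), has a single change that moves the number beyond the scatter. The step also shows that growth inhibition here does not depend on keeping the hydrogen-bond donors and acceptors of the 2,4-dihydroxyphenyl group. No measurement given here accounts for the step.

The compounds shown leave open whether an unsubstituted phenyl or a 3,5-dimethoxyphenyl group would match this number. As far as these compounds go, it also remains open whether the step would hold with the 4-chlorobenzyl group of compound 3 on the sulfur.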